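Amide variations in a nitro-sulfone series

The source may hold more compounds than are shown below. What is called first, only, known or untested is meant among the compounds shown, and "the series" means these compounds.

Three compounds are in hand. Compound 1 `CN(Cc1cccc(F)c1)C(=O)CCCNC(=O)c1ccc(S(C)(=O)=O)c([N+](=O)[O-])c1` and compound 3 `CC1CCN(C(=O)CCCNC(=O)c2ccc(S(C)(=O)=O)c([N+](=O)[O-])c2)CC1` share one core; compound 2 `CN(Cc1cccc(F)c1)C(=O)CN(C)C(=O)c1ccc(S(C)(=O)=O)c([N+](=O)[O-])c1` carries a second core, and the difference between the two cores is not broken down here. In an assay on isolated protein for inhibition of thyroid hormone receptor alpha (Homo sapiens), read by fluorescence polarization (on this read-out lower numbers stand for stronger inhibition and higher numbers for weaker inhibition), compound 1 gives only a limit, > 60000 nM. In this assay compound 3 likewise gives only a limit, > 60000 nM. For compound 2 this assay also reports only a limit, > 60000 nM. The change from compound 1 to compound 3 is 4-methylpiperidin-1-yl in place of (3-fluorobenzyl)(methyl)amino on a carbonyl carbon, and the step is a step that the two limits leave unreadable from compound 1 to compound 3. All three values sit at the limit of > 60000 nM in this assay, at which 3 of the 3 values shown sit. Compound 4 `CC1CCN(C(=O)CN(C)C(=O)c2ccc(S(C)(=O)=O)c([N+](=O)[O-])c2)CC1` is still unmeasured; it stands to compound 2 as compound 3 stands to compound 1: 4-methylpiperidin-1-yl in place of (3-fluorobenzyl)(methyl)amino on a carbonyl carbon. Going by the values given here, because every value so far lies at the limit of > 60000 nM in this assay, at which 3 of the 3 values shown sit, the step that the limit leaves unreadable from compound 2 to compound 4 is expected to be unreadable in the same way. Compound 4 is therefore expected at about 80000 nM, within 30000 nM to 200000 nM, most likely again reported only as a limit.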

Compound 4, half-maximal inhibitory concentration: > 60000 nM
Compound 4: no number, only a limit (the forecaster's own chance of this, stated with the estimate: 90%); the middle value is on the limit's open side.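

No step can be read from compound 2 to compound 4, because both give only a limit in this assay: the limit of > 60000 nM in this assay, at which 4 of the 4 values shown sit.

The compounds shown leave open how the two cores compare and which amide, if any, gives a readable inhibition value.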